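The source may hold more compounds than are shown below. What is called first, only, known or untested is meant among the compounds shown, and "the series" means these compounds.

Compound 3 `CN(C)C(=O)C[C@H](CSc1ccccc1)Nc1c(C(=O)N/N=C/c2cccnc2)cnc2ccc(F)cc12` belongs to a small family built on one shared core, whose members differ only in the aromatic group attached to the carbon with a double bond to nitrogen. In an ADME assay on Vero cells (Chlorocebus sabaeus) for cytotoxicity, read by MTT assay, with a stated time of 72 h (a lower number here means a stronger inhibitor, a higher number a weaker inhibitor), compound 3 gives > 62.5 ug/mL, which is a limit of the assay and not a measured number. Compound 2 `CN(C)C(=O)C[C@H](CSc1ccccc1)Nc1c(C(=O)N/N=C/c2ccc(F)cc2)cnc2ccc(F)cc12` carries 4-fluorophenyl on that carbon, and in this assay compound 2 likewise gives > 62.5 ug/mL, again only a limit. Compound 1 `COc1ccc(/C=N/NC(=O)c2cnc3ccc(F)cc3c2N[C@@H](CSc2ccccc2)CC(=O)N(C)C)cc1` is the third relative; in this assay compound 1 has "not determined" (no result reported). Among the compounds with values here, the single step that can be followed, a step that the two limits leave unreadable from compound 2 to compound 3, cannot be given a size because the limit of > 62.5 ug/mL in this assay, at which 2 of the 3 values shown sit, hides both of its ends.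

Compound 4 `COc1ccc(/C=N/NC(=O)c2cnc3ccc(F)cc3c2N[C@@H](CSc2ccccc2)CC(=O)N(C)C)cc1O` is the next member, reached by the change (3-hydroxy-4-methoxyphenyl in place of pyridin-3-yl on a carbon with a double bond to nitrogen). Within the data shown here, only the step from compound 2 to compound 3 bears on it, and that step is unreadable, so there is no measured guide to direction or size. For compound 4 the expected step is a step that the limit leaves unreadable from compound 3 to compound 4, that is, nothing beyond the scatter. Compound 4 is expected most likely to return as a limit again. The estimate for compound 4 in this assay is 100 ug/mL, with a range from 50 ug/mL to 250 ug/mL.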

Compound 4, half-maximal inhibitory concentration: > 62.5 ug/mL
Compound 4 gave a limit, no number (the forecaster's own chance of this, stated with the estimate: 80%); the middle value is on the limit's open side.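

Compound 4 gives only a limit, as do compound 2 and compound 3, so no step among these three compounds can be read, because all of them sit at one ceiling: the limit of > 62.5 ug/mL in this assay, at which 3 of the 4 values shown sit.

The compounds shown leave open where their true values lie, and whether the aromatic group on the carbon with a double bond to nitrogen alters the reading in this assay at all.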